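The source may report more compounds than this note shows. Statements on the series, on what has been measured and on what is new or still open speak of the compounds shown alone.

Measured so far:
- compound 1, `CCN(Cc1cccs1)C(=O)COc1ccc(C(=O)O)cc1`: "not active" (no number reported)
- compound 2, `CCN(Cc1cccs1)C(=O)COc1ccc(F)cc1`: 422 nM
- compound 3, `Cc1ccc(OCC(=O)N(CCO)Cc2cccs2)cc1`: 900 nM

All three share a core in which a thiophene-bearing arm and a second arm sit on an amide-type nitrogen. In an assay on HEK293 cells for agonist activity at transient receptor potential cation channel subfamily M member 8 (Homo sapiens), read by fluorescence and calcium flux, with a stated time of 15 min (a higher number here means that more compound is needed for the effect, a lower number that less compound is needed), compound 1 is reported as "not active" (no number reported), with no number given. Compound 2 gives 422 nM in this assay. Compound 3 gives 900 nM, the higher of the two numbers, and its gap to compound 2 lies beyond the usual scatter, so compound 3 needs more compound than compound 2 for the same effect.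

The next compound, compound 4, `Cc1ccc(OCC(=O)N(Cc2cccs2)C(C)C)cc1`, differs from compound 3 in a single place:

isopropyl in place of 2-hydroxyethyl on an amide-type nitrogen

For the measured compounds named here, no step between two measured compounds isolates this change, so the expectation rests on the two numbers alone. Compound 2 carries a plain carbon chain on the same nitrogen and gives the lower number, which points toward a somewhat lower number for compound 4 than for compound 3, though the two also differ elsewhere. The expected step from compound 3 to compound 4 is a 1.6-fold lower number from compound 3 to compound 4 (0.21 log units; within the scatter), a modest gain that may not clear the scatter. Compound 4 is estimated at 550 nM, within a range of 200 nM to 1500 nM.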

Compound 4, half-maximal effective concentration: 70 nM
Compound 4: middle estimate off by 7.9-fold (0.90 log units), on the high side; measured number outside the range, below it.
By their numbers in this assay, from the lowest: compound 4; then compound 2; then compound 3.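

In this assay, putting isopropyl in place of 2-hydroxyethyl on the amide-type nitrogen gives a 13-fold lower number from compound 3 to compound 4 (1.11 log units; beyond the scatter), a large step well beyond the scatter, so the compound's activity depends strongly on which group sits at this position. The two groups both hold 3 heavy atoms, and neither has a ring or a net charge, so the count of heavy atoms stays the same while one oxygen gives way to carbon and the hydrogen-bond donor and acceptor of 2-hydroxyethyl disappear. No measurement shown here explains why the number falls so far, and the reason remains unknown.

This single pair changes the atoms and the shape of the group together, so it cannot say whether losing the hydroxyl or gaining the branched isopropyl matters more; a straight propyl chain or a 2-methoxyethyl group on the same nitrogen would be needed to pull those apart. The compounds shown also leave open how far this position tolerates larger groups, such as a cyclohexyl ring, or a chain ending in an amine.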